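Moving the hydroxyl on the hydroxyphenyl group

The compounds below may be only part of what the source reports. "The series", "measured", "known", "first", "only" and "open" are said of these compounds alone.

- Compound 1 `Oc1cccc(-c2cc(-c3ccccc3)nc(-c3ccccc3)c2)c1`: 18000 nM
- Compound 2 `Oc1cccc(-c2cc(-c3ccccc3)nc(-c3cccnc3)c2)c1`: 18400 nM
- Compound 3 `Oc1cccc(-c2cc(-c3ccccc3)nc(-c3ccncc3)c2)c1`: 18700 nM

All values come from a functional assay on HCT-15 cells (Homo sapiens) for cytotoxicity, read by ELISA, with a stated time of 2 days; a higher number here means a weaker inhibitor, a lower number a stronger inhibitor. Compound 3 stands level with the other two, as a 1.0-fold higher number from compound 1 to compound 3 (0.02 log units; within the scatter) and a 1.0-fold higher number from compound 2 to compound 3 (0.01 log units; within the scatter) show. Compound 4 `Oc1ccc(-c2cc(-c3ccccc3)nc(-c3ccncc3)c2)cc1` carries 4-hydroxyphenyl in place of 3-hydroxyphenyl on an aromatic carbon, opposite the ring nitrogen (4-hydroxyphenyl in place of 3-hydroxyphenyl on an aromatic carbon). For the measured compounds named here, no measured step moves the hydroxyl, so the evidence is indirect. The nearest guide is the exchange of the other aryl group, where a 1.0-fold higher number from compound 1 to compound 2 (0.01 log units; within the scatter) also stayed small. No step beyond the scatter is expected, and no direction is favoured. The expected change is a 1.0-fold lower number from compound 3 to compound 4 (0.02 log units; within the scatter). For compound 4 the estimated value is 18000 nM, with an expected range of 7000 nM to 40000 nM.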

Compound 4, half-maximal inhibitory concentration: 11700 nM
Beside the measured number, compound 4's estimate is 1.5-fold (0.19 log units) above it; the range from low to high includes it.
By their numbers in this assay, from the lowest: compounds 4, 1, 2 and 3 (each within the scatter of the next).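

For the compounds shown here, this is the first direct reading of the hydroxyl's location: in this assay, 4-hydroxyphenyl in place of 3-hydroxyphenyl gives a 1.6-fold lower number from compound 3 to compound 4 (0.20 log units; within the scatter), so this change on the carbon opposite the ring nitrogen stays as small as repeat measurements allow. The exchange of the hydroxyphenyl group thus joins the exchanges of the other aryl group in producing no step beyond the scatter. No available data offer an explanation for this result.

Still open, going by these compounds, is whether an amine or a carboxylic acid in place of the hydroxyl would give a step beyond the scatter.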